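Aryl amide swap on the anilide nitrogen of the shared core

This account rests on a few compounds, and the source may have more. Where it says the series, first, only, none or still open, it means among the compounds named here.

Compound 1 `N=c1oc2c(O)cccc2cc1C(=O)Nc1cccc(F)c1` gives > 10000 nM in an assay on isolated protein for inhibition of aldo-keto reductase family 1 member C4 (Homo sapiens), using NADPH (a higher number here means a weaker inhibitor, a lower number a stronger inhibitor), which is a limit of the assay.
Compound 2 `Cc1ccc(NC(=O)c2cc3cccc(O)c3oc2=N)cc1` gives > 10000 nM in this assay, again a limit of the assay.

Compound 1 stands only at the limit of > 10000 nM in this assay, at which 2 of the 2 values shown sit. The step that the two limits leave unreadable from compound 1 to compound 2 cannot be read, since both ends are limits. Compound 3 `CCc1cccc(NC(=O)c2cc3cccc(O)c3oc2=N)c1` differs from compound 1 by ethyl in place of fluoro on an aromatic carbon. Among the compounds with values here, no measured step gives a readable size for a change of this kind, so no direction can be drawn from the series. The step that the limit leaves unreadable from compound 1 to compound 3 is therefore expected to stay unreadable against the limit. Compound 3 is expected at 20000 nM (range 8000 nM to 100000 nM) in this assay, most likely reported again only as a limit.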

Compound 3, half-maximal inhibitory concentration: > 10000 nM
Compound 3: no number, only a limit; the forecaster's own chance of this, stated with the estimate: 85%; the middle value does not contradict the limit.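

No step can be read from compound 1 to compound 3, since both compounds stand only at a limit of the assay: the limit of > 10000 nM in this assay, at which 3 of the 3 values shown sit.

As far as these compounds go, whether any group on this aryl ring of the shared core changes inhibition in this assay stays open.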